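The source may hold more compounds than are shown below. What is called first, only, known or untested is meant among the compounds shown, and "the series" means these compounds.

In an assay on cells for inhibition of HSP60/HSP10 (Homo sapiens), with a stated time of 60 min (a higher number here means a weaker inhibitor, a lower number a stronger inhibitor), the measured compounds are:

Compound 1 `O=S(=O)(Nc1ccc(-c2nc3ccccc3o2)cc1)c1cccc(Cl)c1`: 54000 nM.
Compound 2 `CCc1ccc(S(=O)(=O)Nc2ccc(-c3nc4ccccc4o3)cc2)cc1`: > 100000 nM, which is a limit of the assay and not a number.
Compound 3 `Cc1ccccc1S(=O)(=O)Nc1ccc(-c2nc3ccccc3o2)cc1`: 85000 nM.

Compound 3 stands at the highest of the two numbers shown; the nearest is compound 1, and the step of a 1.6-fold higher number from compound 1 to compound 3 (0.20 log units; within the scatter) lies within the scatter. Compound 2 sits at the limit, as noted in the limit of > 100000 nM in this assay, at which 1 of the 3 values shown sits.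

Compound 4 `O=S(=O)(Nc1ccc(-c2nc3ccccc3o2)cc1)c1ccc(Cl)cc1` differs from compound 3 by 4-chlorophenyl in place of 2-methylphenyl on a sulfonyl sulfur. The step that bears most closely on this exchange is a 1.6-fold higher number from compound 1 to compound 3 (0.20 log units; within the scatter), which also swaps a chlorophenyl against the 2-methylphenyl. The steps of an at least 1.8-fold higher number from compound 1 to compound 2 (0.26 log units; that floor lies within the scatter) and an at least 1.1-fold lower number from compound 2 to compound 3 (0.07 log units; that floor lies within the scatter) likewise change only the group on the sulfonyl sulfur, and neither reaches beyond the scatter. Going by the values given here, no step therefore supports a change beyond the scatter in this assay; a modestly lower number is expected for compound 4 because compound 1 with its chlorophenyl gives 54000 nM. Compound 4 is expected at 60000 nM, in the range 30000 nM to 120000 nM. The expected step is a 1.4-fold lower number from compound 3 to compound 4 (0.15 log units; within the scatter).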

Compound 4, half-maximal inhibitory concentration: 61000 nM
For compound 4 the middle estimate is 1.0-fold (0.01 log units) below the measured one; low and high end bracket the measured number.
By their numbers in this assay, from the lowest: compounds 1, 4 and 3 (each within the scatter of the next). At a limit, above all of these: compound 2.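

In this assay, 4-chlorophenyl in place of 3-chlorophenyl on the sulfonyl sulfur gives a 1.1-fold higher number from compound 1 to compound 4 (0.05 log units; within the scatter), and 4-chlorophenyl in place of 2-methylphenyl gives a 1.4-fold lower number from compound 3 to compound 4 (0.14 log units; within the scatter), so neither exchange separates these compounds. Chloro in place of ethyl on an aromatic carbon gives an at least 1.6-fold lower number from compound 2 to compound 4 (0.21 log units; that floor lies within the scatter), which also does not establish a change beyond the scatter. The value of compound 2 remains a limit and not a number: the limit of > 100000 nM in this assay, at which 1 of the 4 values shown sits.

As far as these compounds go, the aromatic ring on the sulfonyl sulfur carries only chloro, methyl or ethyl here, so it remains open whether an amine or a carboxylic acid on that ring, or a longer chain in its place, would give a step beyond the scatter. Also open, from the compounds shown here alone, is how a change elsewhere in the shared core would read in this assay.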